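Phenethyl ester on a thiazolyl dihydropyridine

The compounds below may be only part of what the source reports. "The series", "measured", "known", "first", "only" and "open" are said of these compounds alone.

Measured so far:
Compound 1, `CCOC(=O)C1=C(C)NC(C)=C(C(=O)OC)C1c1csc(-c2ccc(Cl)cc2)n1`: 22000 nM
Compound 2, `CCOC(=O)C1=C(C)NC(C)=C(C(=O)OC(C)(C)C)C1c1csc(-c2ccc(Cl)cc2)n1`: 91000 nM

In an assay on isolated protein for antagonist activity at Voltage-dependent L-type calcium channel subunit alpha-1C (Cavia porcellus), with a stated time of 15 min (on this read-out lower numbers stand for stronger inhibition and higher numbers for weaker inhibition), compound 1 gives 22000 nM and stands at the lower of the two numbers; its neighbour compound 2 sits a 4.1-fold higher number from compound 1 to compound 2 (0.62 log units; beyond the scatter) away, a step made by putting tert-butyl in place of methyl on an oxygen next to a carbonyl group. The unmeasured compound 3, `COC(=O)C1=C(C)NC(C)=C(C(=O)OCCc2ccccc2)C1c1csc(-c2ccc(Cl)cc2)n1`, carries a different ester change on the same core: phenyl in place of hydrogen on a saturated chain carbon, two bonds along the chain from an oxygen next to a carbonyl group. Among the compounds with values here, the one measured step that bears on it is the enlargement of an ester group, which moved the number upward by a 4.1-fold higher number from compound 1 to compound 2 (0.62 log units; beyond the scatter). Phenethyl is likewise a larger ester than the ethyl of compound 1, though as a chain rather than a branched group, so the account expects a smaller upward shift than that seen with tert-butyl, or none beyond the scatter. The step from compound 1 to compound 3 is therefore estimated at a 1.5-fold higher number from compound 1 to compound 3 (0.16 log units; within the scatter). Compound 3 is expected to give about 32000 nM, within a range of 11000 nM to 95000 nM.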

Compound 3, half-maximal inhibitory concentration: 10200 nM
Compound 3: middle estimate off by 3.1-fold (0.50 log units), on the high side, and the stated range ends above it.
By their numbers in this assay, from the lowest: compound 3; then compound 1; then compound 2.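

In this assay, the phenyl placed on a saturated chain carbon, two bonds along the chain from an oxygen next to a carbonyl group, gives a 2.2-fold lower number from compound 1 to compound 3 (0.33 log units; beyond the scatter). Enlarging an ester group therefore does not always raise the number on this read-out: the only earlier step, to the tert-butyl ester, went the other way with a 4.1-fold higher number from compound 1 to compound 2 (0.62 log units; beyond the scatter), so compound 2 stands against any rule that a larger ester gives weaker inhibition. The compounds shown offer no measured property or other finding that would explain this difference in direction between the phenethyl and tert-butyl esters.

What the compounds leave open is how much of the change belongs to the phenyl ring itself and how much to the chain that carries it, since a benzyl ester and a phenylpropyl ester would be needed to separate the two. As far as these compounds go, it also remains open whether a chlorine or a methoxy group on that phenyl ring, or an amine at the end of the chain, would move the number further in this assay or return it towards that of compound 1.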